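Chain extension on the core of compound 2

The source may hold more compounds than are shown below. What is called first, only, known or untested is meant among the compounds shown, and "the series" means these compounds.

Of the compounds shown here, two have been measured in an assay on microsomes from intestine for inhibition of acyl-CoA:cholesterol acyltransferase (Oryctolagus cuniculus); on this read-out higher numbers stand for weaker inhibition and lower numbers for stronger inhibition. Compound 1 `CCCCCCCC/C=C/CCCCCCCC(=O)Nc1ccccc1OC` gives 8000 nM in this assay. Within the data shown here, compound 2 `CCCCCCCC(C)(C)C(=O)Nc1c(OC)cc(OC)cc1OC` gives 180 nM in this assay, the lowest of the two numbers; compound 1, the only other measured compound, stands at a number higher by a margin beyond the scatter. Among the measured compounds shown here, the two measured compounds differ in several places at once, so no single-point step between measured compounds is available to set the size of the next one.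

Compound 3 `CCCCCCCCCCCCC(C)(C)C(=O)Nc1c(OC)cc(OC)cc1OC` differs from compound 2 in one place: pentyl in place of hydrogen on a saturated chain carbon, eight bonds along the chain from a carbonyl carbon. Nothing measured speaks directly to a change of this kind on the shared core.

With nothing measured bearing on chain length alone, compound 3 is expected to stand near compound 2 or a little lower, the estimated step being a 2.0-fold lower number from compound 2 to compound 3 (0.30 log units; within the scatter). For compound 3 the estimate in this assay is 90 nM, with a range from 25 nM to 350 nM.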

Compound 3, half-maximal inhibitory concentration: 63 nM
Beside the measured number, compound 3's estimate is 1.4-fold (0.15 log units) above it; measured number inside the range.
By their numbers in this assay, from the lowest: compound 3; then compound 2; then compound 1.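

In this assay, among these compounds, pentyl in place of hydrogen on a saturated chain carbon, eight bonds along the chain from a carbonyl carbon, gives a 2.9-fold lower number from compound 2 to compound 3 (0.46 log units; beyond the scatter), a modest step but one beyond the usual scatter, and the first step on the shared core that can be read at a single place. This position therefore accepts an all-carbon extension with no ring, no hydrogen-bond donors or acceptors and no net charge, and inhibition does not weaken; the number moves lower on this core. No measurement bears on what lies behind the step, so it stands as an observation on this pair alone.

On these data alone, a single step gives one point and no trend, so whether a longer chain would lower the number further, hold it level or raise it stays open, as does the effect of a shorter chain such as propyl. Also open, as far as these compounds go, is whether this chain end accepts anything other than plain carbon, for instance a terminal amine or a carboxylic acid in place of pentyl.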